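Aryl Swap at the Core of a Cytotoxic Series

This account rests on a few compounds, and the source may have more. Where it says the series, first, only, none or still open, it means among the compounds named here.

Compound 1 `CCOC(=O)c1c(-c2ccccc2OC)c(C#N)c(=O)n(/N=C(\C)c2ccc(NS(=O)(=O)c3ccc(Cl)cc3)cc2)c1N` gives 11400 nM in a functional assay on HepG2 cells (Homo sapiens) for cytotoxicity, read by sulforhodamine B assay, with a stated time of 48 h; on this read-out higher numbers stand for weaker inhibition and lower numbers for stronger inhibition.
Compound 2 `CCOC(=O)c1c(-c2ccc(OC)cc2)c(C#N)c(=O)n(/N=C(\C)c2ccc(NS(=O)(=O)c3ccc(Cl)cc3)cc2)c1N` gives 61700 nM in this assay.
Compound 3 `CCOC(=O)c1c(-c2ccccc2Cl)c(C#N)c(=O)n(/N=C(\C)c2ccc(NS(=O)(=O)c3ccc(Cl)cc3)cc2)c1N` gives 11400 nM in this assay.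

Compound 3 stands level with compound 1: no change at the digits printed from compound 1 to compound 3 (within the scatter). Going by the values given here, both sit at the low end of the three numbers, and the only step beyond the scatter is a 5.4-fold lower number from compound 2 to compound 3 (0.73 log units; beyond the scatter), the mirror of a 5.4-fold higher number from compound 1 to compound 2 (0.73 log units; beyond the scatter).

Compound 4 `CCOC(=O)c1c(-c2cccc([N+](=O)[O-])c2)c(C#N)c(=O)n(/N=C(\C)c2ccc(NS(=O)(=O)c3ccc(Cl)cc3)cc2)c1N` carries a new aryl group on the shared core: 3-nitrophenyl in place of 2-chlorophenyl on an aromatic carbon. Among the compounds with values here, two measured steps bear on this. Exchanging one group for another at the same position on the aryl ring left the number unchanged, as seen in no change at the digits printed from compound 1 to compound 3 (within the scatter). Moving a group to another position on that ring gave a modest rise, as seen in a 5.4-fold higher number from compound 1 to compound 2 (0.73 log units; beyond the scatter). Compound 4 changes both the group and its position, so a small rise is expected, a 1.4-fold higher number from compound 3 to compound 4 (0.15 log units; within the scatter), though the scatter could swallow it. Compound 4 is therefore estimated at 16000 nM, within a range of 5000 nM to 50000 nM.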

Compound 4, half-maximal inhibitory concentration: 29700 nM
Estimate against measurement, compound 4: 1.9-fold (0.27 log units) below; the range from low to high includes it.
By their numbers in this assay, from the lowest: compounds 1 and 3 (each within the scatter of the next); then compound 4; then compound 2.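

In this assay, the 3-nitrophenyl group gives a 2.6-fold higher number from compound 3 to compound 4 (0.42 log units; beyond the scatter) and a 2.6-fold higher number from compound 1 to compound 4 (0.42 log units; beyond the scatter), so the level shared by the 2-chlorophenyl and 2-methoxyphenyl groups does not extend to every aryl group at this place on the core. Compound 4 also stands apart from the 4-methoxyphenyl group, with a 2.1-fold lower number from compound 2 to compound 4 (0.32 log units; beyond the scatter), so this one place now gives three separate levels, although the group and its ring position both differ in these steps. Nothing available explains these differences.

The compounds shown leave open whether the higher number follows the nitro group or its ring position, a question that a 2-nitrophenyl or 3-chlorophenyl group would help to separate. As far as these compounds go, how an unsubstituted phenyl, or an aryl ring carrying an amine or a carboxylic acid, would read at this place also remains open.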